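This account rests on a few compounds, and the source may have more. Where it says the series, first, only, none or still open, it means among the compounds named here.

Of the compounds shown here, two have so far been measured in a functional assay on THP-1 cells (Homo sapiens) for inhibition, read by sulforhodamine B assay, tested at 10 uM; a higher number here means more inhibition of growth at the concentration tested, a lower number less inhibition of growth. Compound 1 `CC(=O)N1N=C(c2ccc(OCc3cn(Cc4ccc([N+](=O)[O-])cc4)nn3)cc2)CC1c1ccccc1` gives 0% in this assay. Compound 2 `COc1cc(C2CC(c3ccc(Br)cc3)=NN2C(C)=O)ccc1OCc1cn(Cc2ccc([N+](=O)[O-])cc2)nn1` gives 1% in this assay. Compound 2 thus holds the higher of the two numbers, but compound 1 lies within the scatter of it, so the two results cannot be told apart; neither shows growth inhibition worth the name at the tested concentration. Compound 1 and compound 2 differ at more than one place, so no single step can be read from them.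

Compound 3 `COc1cc(C2CC(c3cc(OC)c(OC)c(OC)c3)=NN2C(C)=O)ccc1OCc1cn(Cc2ccc([N+](=O)[O-])cc2)nn1` is the next compound, and it differs from compound 2 in one place: 3,4,5-trimethoxyphenyl in place of 4-bromophenyl on a carbon with a double bond to nitrogen. For the measured compounds named here, no measured pair shows what such an exchange does in this assay, so the expectation rests only on where the series stands. Because compound 2 gives 1% and compound 1 gives 0%, there is no room for a downward move, and any upward move is unsupported by data. Compound 3 is therefore estimated at 10%, within a range from 0% to 40%. That estimate means an expected step of a number 9 percentage points higher from compound 2 to compound 3 (within the scatter), which would stay within the scatter.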

Compound 3, percent growth inhibition at one concentration: 29%
Beside the measured number, compound 3's estimate is 19 percentage points below it; the measured number falls inside the stated range.
By their numbers in this assay, from the lowest: compounds 1 and 2 (each within the scatter of the next); then compound 3.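

In this assay, for the compounds shown here, putting 3,4,5-trimethoxyphenyl in place of 4-bromophenyl on a carbon with a double bond to nitrogen gives a number 28 percentage points higher from compound 2 to compound 3 (beyond the scatter), the first step that can be read at all. It shows that the group at this place on the shared core can change the read-out at the tested concentration, which the earlier pair, differing at more than one place, could not show. The exchange removes a bromine and brings in three hydrogen-bond acceptors on a larger group, but this single step cannot separate those changes, and no measurement at hand explains the rise.

Going by these compounds, it remains open whether a single methoxy group on the phenyl ring would give part of this step, and whether an amine or a carboxylic acid at the same place would raise or lower the number. On these data alone, it is also open whether the step would persist if the nitro group elsewhere on the molecule gave way to another group, such as a nitrile.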